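A few compounds are considered here, and "the series" means these few. Any claim that something is new, unique, unknown or untested is made for them only; others in the source may bear on it.

Working notes on the series. In a functional assay on HeLa cells (Homo sapiens) for cytotoxicity, read by ELISA, with a stated time of 4 days (on this read-out lower numbers stand for stronger inhibition and higher numbers for weaker inhibition), compound 1 `Cc1ccsc1-c1cc(-c2ccoc2)cc(-c2ccco2)n1` gives 30500 nM and compound 2 `Cc1cccc(-c2cc(-c3ccoc3)cc(-c3ccc(Cl)s3)n2)c1` gives 23600 nM so the two stand within the scatter of each other. Compound 2 is therefore not set apart by the numbers available. Compound 3 `Clc1ccc(-c2cc(-c3ccoc3)cc(-c3cccnc3)n2)s1` keeps the furan-3-yl and 5-chlorothiophen-2-yl groups of compound 2 and carries pyridin-3-yl in place of 3-methylphenyl on an aromatic carbon and it awaits measurement. Among the measured compounds shown here, no measured pair isolates this change, so the data give no direct size for it. In this assay a step no larger than the scatter is expected, with a slight lean toward a higher number and no firm direction. That expectation rests on compound 1 at 30500 nM and compound 2 at 23600 nM which differ in more than one place and still lie within the scatter. The estimated change is a 1.2-fold higher number from compound 2 to compound 3 (0.07 log units; within the scatter) and so stays within the scatter. For compound 3 the expected value is 28000 nM with an estimated span from 12000 nM to 65000 nM as the likely range.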

Compound 3, half-maximal inhibitory concentration: 20000 nM
The estimate for compound 3 lay 1.4-fold (0.15 log units) above the measured number; the range from low to high includes it.
By their numbers in this assay, from the lowest: compounds 3, 2 and 1 (each within the scatter of the next).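

In this assay, placing pyridin-3-yl in place of 3-methylphenyl, on the aromatic carbon next to the ring nitrogen, gives a 1.2-fold lower number from compound 2 to compound 3 (0.07 log units; within the scatter) and is the only step shown between compounds that differ in one place. Among the compounds shown here, this gives the exchange a direct size for the first time in these notes: at this position, a six-membered aromatic ring of carbon only and a six-membered aromatic ring with a nitrogen leave compound 2 and compound 3 within the scatter of each other, even though pyridin-3-yl carries a hydrogen-bond acceptor and 3-methylphenyl carries none. No measurement shown accounts for this result or links it to any property of either group.

The compounds shown hold only aromatic rings at this position, so it remains open whether an amine, a carboxylic acid or a longer alkyl chain there would give a step beyond the scatter. On these data alone, the furan-3-yl and 5-chlorothiophen-2-yl groups are also not varied alone in any pair, so the size of a single exchange at either place remains unknown.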